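Removing the last chain methyl in the dipeptide series

The compounds below may be only part of what the source reports. "The series", "measured", "known", "first", "only" and "open" are said of these compounds alone.

Compound 3 `C#CCN(Cc1ccc2nc(C)nc(O)c2c1)c1ccc(C(=O)N[C@@H](CC(C)C(=O)O)C(=O)N[C@@H](CCC(=O)O)C(=O)O)cc1` gives 8.6 nM in an assay on L1210 cells for inhibition of Thymidylate synthase (Mus musculus) (a higher number here means a weaker inhibitor, a lower number a stronger inhibitor), the lowest of the three numbers. Compound 1 `C#CCN(Cc1ccc2nc(C)nc(O)c2c1)c1ccc(C(=O)N[C@@H](CCC(=O)O)C(=O)N(C)[C@@H](CCC(=O)O)C(=O)O)cc1` gives 11 nM, within the scatter of compound 3, and compound 2 `C#CCN(Cc1ccc2nc(C)nc(O)c2c1)c1ccc(C(=O)N[C@@H](CC(C)(C)C(=O)O)C(=O)N[C@@H](CCC(=O)O)C(=O)O)cc1` gives 18 nM, beyond it. Compound 4 `C#CCN(Cc1ccc2nc(C)nc(O)c2c1)c1ccc(C(=O)N[C@@H](CCC(=O)O)C(=O)N[C@@H](CCC(=O)O)C(=O)O)cc1` differs from compound 3 by hydrogen in place of methyl on a saturated chain carbon bound to a carbonyl carbon and a saturated chain carbon. Among the compounds with values here, the only measured step of the same kind, a 2.1-fold lower number from compound 2 to compound 3 (0.32 log units; beyond the scatter), was a modest drop from the loss of a methyl at a related place. Given that precedent and the closeness of compound 1, the expected step of a 1.2-fold lower number from compound 3 to compound 4 (0.09 log units; within the scatter) is small, either flat or slightly downward. Compound 4 is therefore estimated at 7 nM, with a range from 3 nM to 18 nM.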

Compound 4, inhibition constant: 2 nM
Compound 4: the middle estimate sits 3.5-fold (0.54 log units) above what was measured, and the stated range ends above it.
By their numbers in this assay, from the lowest: compound 4; then compounds 3, 1 and 2 (each within the scatter of the next, the first and the last beyond it).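

Hydrogen in place of methyl on this saturated chain carbon is no small change: it gives a 4.3-fold lower number from compound 3 to compound 4 (0.63 log units; beyond the scatter) in this assay, and with both methyls gone, the carboxymethyl group gives a 9.0-fold lower number from compound 2 to compound 4 (0.95 log units; beyond the scatter). The amide hydrogen in place of methyl on the amide-type nitrogen gives a 5.5-fold lower number from compound 1 to compound 4 (0.74 log units; beyond the scatter), so compound 4, with no methyl at either place, holds the lowest number of the four.

From the compounds shown here alone, whether a longer chain or an amine at this carbon would keep that number remains open. Nothing shown here explains these steps.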